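The source may hold more compounds than are shown below. What is called first, only, known or untested is meant among the compounds shown, and "the series" means these compounds.

Working notes on the hydroxamate series.

Compound 1 `CCOc1cc(C(C)(C)C)ccc1C1=NC(c2ccc(Cl)cc2)C(c2ccc(Cl)cc2)N1C(=O)N1CCN(Cc2ccc(C(=O)NO)cc2)CC1` is the reference point. Among the measured compounds shown here, in an assay on isolated protein for inhibition of E3 ubiquitin-protein ligase Mdm2 (Homo sapiens), read by fluorescence polarization, with a stated time of 30 min (on this read-out higher numbers stand for weaker inhibition and lower numbers for stronger inhibition), compound 1 gives 260 nM, the lower of the two numbers measured so far. Compound 2 `CCOc1cc(C(C)(C)C)ccc1C1=NC(c2ccc(Cl)cc2)C(c2ccc(Cl)cc2)N1C(=O)NCCCCCCCC(=O)Nc1ccccc1N` carries a long open chain ending in an aminophenyl amide in place of the piperazine hydroxamate; in this assay compound 2 gives 1020 nM, a gap to compound 1 that lies beyond the usual scatter.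

Compound 3 `CCOc1cc(C(C)(C)C)ccc1C1=NC(c2ccc(Cl)cc2)C(c2ccc(Cl)cc2)N1C(=O)N1CCN(CCCCCC(=O)NO)CC1` has not been measured. It differs from compound 1 in one place: 4-(hydroxycarbamoyl)butyl in place of 4-(hydroxycarbamoyl)phenyl on a saturated chain carbon bound to an amine nitrogen in a ring. For the measured compounds named here, no measured pair reproduces this change, so the expectation rests on compound 1 alone and on the observation that the open-chain compound 2 gives 1020 nM. For compound 3 a modest weakening is expected, a step of a 1.7-fold higher number from compound 1 to compound 3 (0.24 log units; within the scatter), which may still fall within the scatter. The estimate for compound 3 in this assay is 450 nM, with a range from 180 nM to 1100 nM.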

Compound 3, inhibition constant: 170 nM
The estimate for compound 3 lay 2.6-fold (0.42 log units) above the measured number; measured number outside the range, below it.
By their numbers in this assay, from the lowest: compounds 3 and 1 (each within the scatter of the next); then compound 2.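

In this assay, 4-(hydroxycarbamoyl)butyl in place of 4-(hydroxycarbamoyl)phenyl on a saturated chain carbon bound to an amine nitrogen in a ring gives a 1.5-fold lower number from compound 1 to compound 3 (0.18 log units; within the scatter). At this position, then, the six-membered aromatic ring of carbon only can give way to an open chain with no step beyond the scatter, and the hydroxycarbamoyl end group is carried by either linker. No measurement available here bears on why the two groups read alike.

The compounds shown leave open how the number responds when the hydroxycarbamoyl group at the end of the chain gives way to a carboxylic acid. They also leave open whether a longer chain at this position stays within the scatter of compound 3.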